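Taking the acetyl group off compound 1

The source may hold more compounds than are shown below. What is called first, only, known or untested is meant among the compounds shown, and "the series" means these compounds.

Measured so far in an ADME assay on L6 cells (Rattus norvegicus) for cytotoxicity, read by resazurin assay, with a stated time of 70 h; on this read-out lower numbers stand for an effect already at smaller amounts and higher numbers for an effect only at larger amounts of compound:
compound 1 `CC(=O)Nc1cnc2[nH]c(=O)n([C@H]3CC[C@H](C(C)(C)C)CC3)c(=O)c2c1`: 67000 nM
compound 2 `CC(=O)Nc1cnc2[nH]c(=O)n([C@H]3CC[C@H](C(C)C)CC3)c(=O)c2c1`: 32000 nM
compound 3 `CC[C@H]1CC[C@H](n2c(=O)[nH]c3ncc(NC(C)=O)cc3c2=O)CC1`: 215000 nM

Compound 1 is second highest of the three numbers. Its nearest neighbour lies at a 2.1-fold lower number from compound 1 to compound 2 (0.32 log units; beyond the scatter), and its furthest at a 3.2-fold higher number from compound 1 to compound 3 (0.51 log units; beyond the scatter). Compound 4 `CC(C)(C)[C@H]1CC[C@H](n2c(=O)[nH]c3ncc(N)cc3c2=O)CC1` differs from compound 1 in one place: hydrogen in place of acetyl on a nitrogen on an aromatic ring. Acetamido thus becomes amino.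

Going by the values given here, no measured step touches that place. All three, including a 6.7-fold higher number from compound 2 to compound 3 (0.83 log units; beyond the scatter), alter only the saturated chain on the saturated ring carbon. These steps are modest, though beyond the scatter, and they offer a sense of scale but no direction for the new change. A step of similar modest size is therefore expected in this assay, with a tentative lean towards a lower number that no measurement here supports. The expected change is a 2.2-fold lower number from compound 1 to compound 4 (0.35 log units; beyond the scatter). For compound 4 the estimated value is 30000 nM, with an expected range from 9000 nM to 100000 nM.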

Compound 4, half-maximal effective concentration: 63000 nM
The estimate for compound 4 lay 2.1-fold (0.32 log units) below the measured number, and the stated range covers the measured number.
By their numbers in this assay, from the lowest: compounds 2, 4 and 1 (each within the scatter of the next, the first and the last beyond it); then compound 3.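

In this assay, going by these compounds alone, the nitrogen on the aromatic ring now has a reading of its own: with tert-butyl kept on the saturated ring, going from acetamido to amino gives a 1.1-fold lower number from compound 1 to compound 4 (0.03 log units; within the scatter), so losing the acetyl group produces no step that can be told from the scatter. The earlier steps shown here touched only the saturated chain, including a 6.7-fold higher number from compound 2 to compound 3 (0.83 log units; beyond the scatter), and all three lay beyond the scatter, whereas this single change at the nitrogen stays within it. No evidence is available to explain this result.

The exchange is shown on the tert-butyl compound alone, and whether amino would behave the same way alongside the chains of compound 2 and compound 3 remains open. Also open, from the compounds shown here alone, is what a benzoyl or methanesulfonyl group on this nitrogen, or a carboxylic acid in place of the amino group, would give in this assay.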